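Second trifluoromethyl on the amide aryl of compound 3

The source may hold more compounds than are shown below. What is called first, only, known or untested is meant among the compounds shown, and "the series" means these compounds.

Measured compounds:
compound 1, `COc1cc(Cl)cc(-c2nn(-c3cccc(NC(=O)c4ccc(Cl)c(Cl)c4)c3)cc2-c2ccncc2)c1`, 33.9%
compound 2, `COc1cc(Cl)cc(-c2nn(-c3cccc(NC(=O)Nc4ccc(Cl)c(Cl)c4)c3)cc2-c2ccncc2)c1`, -21%
compound 3, `COc1cc(Cl)cc(-c2nn(-c3cccc(NC(=O)c4cccc(C(F)(F)F)c4)c3)cc2-c2ccncc2)c1`, 21.4%

In a functional assay on MDA-MB-231 cells (Homo sapiens) for inhibition, read by sulforhodamine B assay, with a stated time of 48 h, tested at 10 uM (a lower number here means a stronger effect, a higher number a weaker effect of the compound at the concentration tested), compound 3 gives 21.4%, which places it second highest of the three numbers. Its nearest neighbour is compound 1, and the gap is a number 12.5 percentage points lower from compound 1 to compound 3 (beyond the scatter). Its furthest neighbour is compound 2, and that gap is a number 42.4 percentage points higher from compound 2 to compound 3 (beyond the scatter).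

Compound 4, `COc1cc(Cl)cc(-c2nn(-c3cccc(NC(=O)c4cc(C(F)(F)F)cc(C(F)(F)F)c4)c3)cc2-c2ccncc2)c1`, has not yet been measured in this assay. It differs from compound 3 by trifluoromethyl in place of hydrogen on an aromatic carbon.

For the measured compounds named here, of the measured steps, only the one from compound 1 to compound 3 concerns a change of substituent on the aryl ring attached to the carbonyl, and it was modest: a number 12.5 percentage points lower from compound 1 to compound 3 (beyond the scatter). The step to compound 2 concerns the amide-to-urea change and does not bear on this move. Going by the values given here, no measured pair tests a second trifluoromethyl, so the expected step is small, within or near the scatter, with a slight lean downward: a number 4.4 percentage points lower from compound 3 to compound 4 (within the scatter) is the expected step. For compound 4 the estimate in this assay is 17%, with a range from -3% to 37%.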

Compound 4, a percentage reported as activity, at one concentration (the size of the read-out at that concentration, not a potency): 56.7%
Compound 4: the middle estimate sits 39.7 percentage points below what was measured; measured number above the stated range.
By their numbers in this assay, from the lowest: compound 2; then compound 3; then compound 1; then compound 4.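

In this assay, the second trifluoromethyl on the aryl ring attached to the carbonyl gives a number 35.3 percentage points higher from compound 3 to compound 4 (beyond the scatter) and so a weaker effect at the concentration tested, which shows that adding one group at this place can matter a great deal. The earlier compounds shown here showed only a modest change on this ring, a number 12.5 percentage points lower from compound 1 to compound 3 (beyond the scatter) on exchanging its substituents, and a large step only for the amide-to-urea change, a number 54.9 percentage points lower from compound 1 to compound 2 (beyond the scatter) in the opposite direction. No measurement shown here accounts for the new step.

The compounds shown leave open whether a methyl or an amine at this same place would move the number as trifluoromethyl does. They also leave open whether the urea of compound 2 would respond to a second trifluoromethyl as the amide of compound 3 did.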